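From 2-fluorophenyl to 4-fluorophenyl on a shared core

The source may report more compounds than this note shows. Statements on the series, on what has been measured and on what is new or still open speak of the compounds shown alone.

Compound 1 `COc1cc(-c2ccc(C#N)cc2)ccc1Oc1cc(N)nc(Nc2ccc(C#N)cc2)n1` gives 120000 nM
Compound 2 `COc1cc(Oc2cc(N)nc(Nc3ccc(C#N)cc3)n2)ccc1-c1ccc(C#N)cc1` gives 12900 nM
Compound 3 `Cc1cc(-c2ccccc2F)cc(C)c1Oc1cc(N)nc(Nc2ccc(C#N)cc2)n1` gives 29300 nM

In a toxicity assay on MT4 cells (Homo sapiens) for cytotoxicity, read by MTT assay (a higher number here means that more compound is tolerated, a lower number that less compound is tolerated), compound 3 gives 29300 nM and stands second highest of the three. Its number lies beyond the usual scatter from both of the others, above compound 2 and below compound 1.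

Compound 4 `Cc1cc(-c2ccc(F)cc2)cc(C)c1Oc1cc(N)nc(Nc2ccc(C#N)cc2)n1` differs from compound 3 in one place, with 4-fluorophenyl in place of 2-fluorophenyl on an aromatic carbon. The two have the same atoms, joined differently. Going by the values given here, no measured pair here shows a change of this kind, so the size of this step cannot be read directly from the data. Compound 3 (29300 nM) is the closest measured structure, and the expectation starts from it.

The expected change in this assay is a 1.2-fold lower number from compound 3 to compound 4 (0.07 log units; within the scatter) and is estimated to stay within the scatter, with no firm direction. Compound 4 is estimated at 25000 nM within a range from 8000 nM to 80000 nM until the measurement is available.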

Compound 4, half-maximal cytotoxic concentration: 23100 nM
Compound 4: the middle estimate sits 1.1-fold (0.03 log units) above what was measured; the measured number falls inside the stated range.
By their numbers in this assay, from the lowest: compounds 2, 4 and 3 (each within the scatter of the next, the first and the last beyond it); then compound 1.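

Exchanging 2-fluorophenyl for 4-fluorophenyl on this aromatic carbon, meta to two methyl groups, gives a 1.3-fold lower number from compound 3 to compound 4 (0.10 log units; within the scatter) in this assay. Going by these compounds alone, this pair is the first direct reading of a single change in the set, as the earlier compounds differed from one another in more than one place. At this position, and in this assay alone, the two fluorophenyl groups cannot be told apart, and nothing available offers an explanation for this result.

The compounds shown leave open whether an unsubstituted phenyl, a 3-fluorophenyl or a 4-chlorophenyl group at this position would also stay within the scatter of compound 3. They also leave open whether the same exchange would read alike with methoxy in place of the two methyl groups.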